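The source may report more compounds than this note shows. Statements on the series, on what has been measured and on what is new or still open speak of the compounds shown alone.

Of the compounds shown here, three built on one shared core have been measured in an assay on isolated protein for inhibition of Leucine-rich repeat serine/threonine-protein kinase 2 variant G2019S (Homo sapiens), read by TR-FRET and LanthaScreen, with stated times of 50 min and 30 min, in the presence of a further agent that is not named here; a higher number here means a weaker inhibitor, a lower number a stronger inhibitor. Compound 1, `C[C@@H]1CCCN1c1c(C#N)c2c(N)nc(Nc3cn[nH]c3)nc2n1C`, gives 6 nM. Compound 2, `C[C@@H]1CCCN1c1c(C#N)c2c(N)nc(Nc3cnn(C)c3)nc2n1C`, differs from compound 1 by methyl in place of hydrogen on an aromatic nitrogen; in this assay compound 2 gives 5 nM, and the step of a 1.2-fold lower number from compound 1 to compound 2 (0.08 log units; within the scatter) lies within the scatter, so the two values cannot be told apart. Compound 3, `Cc1n[nH]cc1Nc1nc(N)c2c(C#N)c(N3CCC[C@H]3C)n(C)c2n1`, differs from compound 1 by methyl in place of hydrogen on an aromatic carbon, and in this assay compound 3 gives 27 nM, the step being a 4.5-fold higher number from compound 1 to compound 3 (0.65 log units; beyond the scatter). Compound 3 also stands apart from compound 2, with a 5.4-fold higher number from compound 2 to compound 3 (0.73 log units; beyond the scatter).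

Compound 4, `Cc1nn(C)cc1Nc1nc(N)c2c(C#N)c(N3CCC[C@H]3C)n(C)c2n1`, has not yet been measured. It differs from compound 3 by methyl in place of hydrogen on an aromatic nitrogen. This is the change already seen from compound 1 to compound 2, so it appears in two places among these compounds. The surroundings are not identical: in compound 3 the place is also two ring bonds from the ring atom that bears a methyl group (1 heavy atom), which compound 1 lacks, so the change is the same kind of change rather than the same one. Because the earlier step of a 1.2-fold lower number from compound 1 to compound 2 (0.08 log units; within the scatter) lay within the scatter, the expected step in this assay is a 1.2-fold lower number from compound 3 to compound 4 (0.09 log units; within the scatter). Compound 4 is therefore estimated to give 22 nM in this assay, with a likely range from 10 nM to 55 nM.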

Compound 4, half-maximal inhibitory concentration: 30 nM
For compound 4 the middle estimate is 1.4-fold (0.13 log units) below the measured one; the measured number falls inside the stated range.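

In this assay, methyl in place of hydrogen on the aromatic nitrogen gives a 1.1-fold higher number from compound 3 to compound 4 (0.05 log units; within the scatter), and this change carries over from one core to the other with no difference that can be told from scatter: the same change on two cores in this assay, a 1.2-fold lower number (0.08 log units; within the scatter) from compound 1 to compound 2 and a 1.1-fold higher number (0.05 log units; within the scatter) from compound 3 to compound 4, 1.3-fold (0.12 log units) apart, within the scatter of two such steps. Methyl in place of hydrogen on the aromatic carbon also carries over, giving a 6.0-fold higher number from compound 2 to compound 4 (0.78 log units; beyond the scatter), which agrees with the earlier step on the other core: the same change on two cores in this assay, a 4.5-fold higher number (0.65 log units; beyond the scatter) from compound 1 to compound 3 and a 6.0-fold higher number (0.78 log units; beyond the scatter) from compound 2 to compound 4, 1.3-fold (0.12 log units) apart, within the scatter of two such steps. Both changes together give a 5.0-fold higher number from compound 1 to compound 4 (0.70 log units; beyond the scatter), so among these four compounds the methyl on the aromatic carbon goes with the higher numbers while the methyl on the nitrogen leaves the number within the scatter, but this rests on a single pair of cores and one assay and sets no rule for other cores, or for other groups in these places.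

The compounds shown leave open what larger groups on the same ring nitrogen would do, such as an ethyl group, a longer chain or a chain ending in an amine. They also leave open whether another group on the aromatic carbon, such as a chlorine or an ethyl group, would raise the number as methyl does.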